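Compound 3 to compound 4: a new amine side chain

The compounds below may be only part of what the source reports. "The series", "measured", "known", "first", "only" and "open" are said of these compounds alone.

Compound 3 (`CC(C)N1C(=O)C(=O)N=C1/N=C(\NCc1ccccc1)Nc1ccc(Cl)c(Cl)c1`) gives > 1 h in an in vitro ADME assay on microsomes from liver (Mus musculus) for metabolic stability, read by LC-MS (a lower number here means that the compound disappears faster, a higher number that the compound lasts longer), as a limit, not a number. Compound 1 (`CCON/C(=N\C1=NC(=O)C(=O)N1C(C)C)Nc1ccc(Cl)c(Cl)c1`) gives > 1 h as a limit as well. Compound 2 (`CN/C(=N\C1=NC(=O)C(=O)N1C(C)C)Nc1ccc(Cl)c(Cl)c1`) also gives > 1 h as a limit. The series thus offers a single shared limit so far (the limit of > 1 h in this assay, at which 3 of the 3 values shown sit) and no exact half-life.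

Compound 4 (`CC(C)N1C(=O)C(=O)N=C1/N=C(\NCCN(C)C)Nc1ccc(Cl)c(Cl)c1`) has (dimethylamino)methyl in place of phenyl on a saturated chain carbon bound to an amine nitrogen. The closest measured change is the one that brought this phenyl in (a step that the two limits leave unreadable from compound 2 to compound 3), and the side-chain swaps (a step that the two limits leave unreadable from compound 1 to compound 2) and (a step that the two limits leave unreadable from compound 1 to compound 3) also bear on it. None of the three has a readable size.

With all three compounds at the limit (the limit of > 1 h in this assay, at which 3 of the 3 values shown sit), no step beyond the scatter is expected in this assay, and no direction can be assigned. The expected step is a step that the limit leaves unreadable from compound 3 to compound 4 in this estimate. For compound 4 the estimated half-life is 1.3 h, with an expected range from 0.6 h to 2.8 h as the working figures.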

Compound 4, half-life: > 1 h
Compound 4 was reported as a limit; the forecaster's own chance of this, stated with the estimate: 65%; the middle value does not contradict the limit.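

In this assay compound 4 gives > 1 h, which is a limit. No step can be read from compound 1, compound 2 or compound 3 to compound 4. The compounds shown leave open the exact half-lives and whether these amine side chains differ at all: the limit of > 1 h in this assay, at which 4 of the 4 values shown sit.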